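The source may hold more compounds than are shown below. What is called first, only, known or untested is meant among the compounds shown, and "the series" means these compounds.

Three compounds of this series have so far been measured in a functional assay for inhibition, with Rattus norvegicus as the target; a lower number here means a stronger inhibitor, a higher number a weaker inhibitor:

Compound 1, `CCc1cccc2c(/C=C/C(=O)O)cc(OCc3ccccc3)c(O)c12`: 1900 nM
Compound 2, `CCc1cccc2c(/C=C(\Cc3ccccc3)C(=O)O)cc(OC)c(O)c12`: 2300 nM
Compound 3, `CCc1cccc2c(/C=C(/Cc3ccccc3)C(=O)O)cc(OC)c(O)c12`: 2100 nM

All three numbers sit close together, and compound 3 lies within the usual scatter of both compound 1 and compound 2. Among the compounds with values here, the one directly comparable pair is compound 2 and compound 3, which share every atom and bond and differ only in how the double bond is drawn; the step of a 1.1-fold lower number from compound 2 to compound 3 (0.04 log units; within the scatter) is small, and the fact that compounds 2 and 3 differ only in the configuration as drawn is the only thing that separates them.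

Compound 4, `CCCc1cccc2c(/C=C(/Cc3ccccc3)C(=O)O)cc(OC)c(O)c12`, is the next compound to be measured. It differs from compound 3 by methyl in place of hydrogen on a saturated chain carbon, two bonds along the chain from an aromatic carbon. Within the data shown here, none of the measured steps touches this chain: the only measured step concerns the drawn configuration of the double bond, not the length of the chain. The expectation is therefore a step of about no change at the digits printed from compound 3 to compound 4 (within the scatter), that is, no difference beyond the scatter. Compound 4 is expected to give roughly 2100 nM in this assay, with a range from 900 nM to 5000 nM.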

Compound 4, half-maximal inhibitory concentration: 1600 nM
Beside the measured number, compound 4's estimate is 1.3-fold (0.12 log units) above it; the measured number falls inside the stated range.
By their numbers in this assay, from the lowest: compounds 4, 1, 3 and 2 (each within the scatter of the next).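

Going from an ethyl to a propyl chain, with methyl in place of hydrogen on a saturated chain carbon, two bonds along the chain from an aromatic carbon, gives in this assay a 1.3-fold lower number from compound 3 to compound 4 (0.12 log units; within the scatter). Within the data shown here, this is the first measured change at this chain, and it shows that here the added carbon does not move the number beyond the scatter. That reading rests on a single pair, with the double bond drawn as in compound 3.

On these data alone, whether a butyl chain or an amine in place of the propyl group would shift the number beyond the scatter stays open. Nothing known here bears on why this step has the size it has.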